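The source may report more compounds than this note shows. Statements on the series, on what has been measured and on what is new or still open speak of the compounds shown alone.

Measured compounds:
Compound 1 `Cc1cc(NCc2cccnc2)n2ncc(Br)c2n1`, giving 1800 nM in a functional assay on cells (Homo sapiens), read by thymidine incorporation; on this read-out lower numbers stand for stronger inhibition and higher numbers for weaker inhibition
Compound 2 `CCc1cc(NCc2cccnc2)n2ncc(Br)c2n1`, giving 520 nM in this assay

For the measured compounds named here, compound 2 stands lowest of the two numbers in this assay; its nearest neighbour is compound 1, and that step, a 3.5-fold lower number from compound 1 to compound 2 (0.54 log units; beyond the scatter), is the only measured step in the set. Compound 3 `Brc1cnn2c(NCc3cccnc3)cc(C3CC3)nc12` has not yet been measured. It differs from compound 2 in one place: cyclopropyl in place of ethyl on an aromatic carbon. Going by the values given here, the one step that bears on this change is a 3.5-fold lower number from compound 1 to compound 2 (0.54 log units; beyond the scatter), where a saturated carbon group replacing hydrogen on that aromatic carbon brought a modest lowering. Going on from ethyl to cyclopropyl is a smaller alteration than adding a group where none stood, so the expected step in this assay is a 1.5-fold lower number from compound 2 to compound 3 (0.17 log units; within the scatter), a slight lowering that may not clear the scatter. Compound 3 is therefore estimated at 350 nM in this assay, within 150 nM to 900 nM.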

Compound 3, half-maximal inhibitory concentration: 1500 nM
Estimate against measurement, compound 3: 4.3-fold (0.63 log units) below; the whole stated range lies below it.
By their numbers in this assay, from the lowest: compound 2; then compounds 3 and 1 (each within the scatter of the next).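

On this aromatic carbon, the advantage of ethyl did not carry over to cyclopropyl: this assay shows a 2.9-fold higher number from compound 2 to compound 3 (0.46 log units; beyond the scatter) for this change. Cyclopropyl instead left the read-out level with methyl, with a 1.2-fold lower number from compound 1 to compound 3 (0.08 log units; within the scatter) as the step between those two groups, so among these three compounds the read-out does not simply follow the presence of a larger saturated carbon group, and ethyl alone stands apart. The data shown offer no measurement that would explain this difference between ethyl and cyclopropyl.

From the compounds shown here alone, whether the advantage belongs to ethyl alone remains open, since a longer chain such as propyl or a branched group such as isopropyl could side with either compound 2 or compound 3. Going by these compounds, how a methoxy group or an amine would behave on this carbon also remains open.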